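This account rests on a few compounds, and the source may have more. Where it says the series, first, only, none or still open, it means among the compounds named here.

Three measured compounds share one core: compound 1 `COc1cc(-c2nn(-c3ccc(NC(=O)Nc4ccc(Cl)c(Cl)c4)cc3)cc2-c2ccncc2)ccc1Cl`, compound 2 `COc1cc(-c2nn(-c3ccc(NC(=O)c4ccc(Cl)c(Cl)c4)cc3)cc2-c2ccncc2)ccc1Cl` and compound 3 `COc1cc(-c2nn(-c3ccc(NC(=O)c4ccc(Cl)c(C(F)(F)F)c4)cc3)cc2-c2ccncc2)ccc1Cl`. In a functional assay on LOX IMVI cells (Homo sapiens) for antiproliferative activity, read by sulforhodamine B assay, with a stated time of 48 h (on this read-out higher numbers stand for weaker inhibition and lower numbers for stronger inhibition), compound 1 gives 1980 nM, compound 2 gives 2760 nM and compound 3 gives 1560 nM. Compound 2 holds the highest of the three numbers, yet every step among them stays inside the scatter: a 1.4-fold higher number from compound 1 to compound 2 (0.14 log units; within the scatter), a 1.8-fold lower number from compound 2 to compound 3 (0.25 log units; within the scatter) and a 1.3-fold lower number from compound 1 to compound 3 (0.10 log units; within the scatter). All three steps concern the group on the carbonyl carbon of the amide or urea, and none of them separates the compounds in any meaningful way.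

Compound 4 `O=C(Nc1ccc(-n2cc(-c3ccncc3)c(-c3ccc(Cl)c(O)c3)n2)cc1)c1ccc(Cl)c(Cl)c1` is not yet measured. It differs from compound 2 in one place: hydrogen in place of methyl on an oxygen on an aromatic ring. Among the compounds with values here, no measured step touches this oxygen, so the three steps give no direct guide for the change. What they do show is that single-group changes in this series have so far produced differences within the scatter. The working expectation for compound 4 in this assay is therefore a number close to that of compound 2. The expected step is a 1.0-fold lower number from compound 2 to compound 4 (0.01 log units; within the scatter), within the scatter. Compound 4 is estimated at 2700 nM, with a range from 1000 nM to 7500 nM.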

Compound 4, half-maximal inhibitory concentration: 1450 nM
Estimate against measurement, compound 4: 1.9-fold (0.27 log units) above; the range from low to high includes it.
By their numbers in this assay, from the lowest: compounds 4, 3, 1 and 2 (each within the scatter of the next).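

Within the data shown here, this is the first measured change on the oxygen of the 4-chloro-3-methoxyphenyl group, whereas the earlier steps all concerned the group on the carbonyl carbon. In this assay, methoxy to hydroxy gives a 1.9-fold lower number from compound 2 to compound 4 (0.28 log units; within the scatter), so removing the methyl from this oxygen and leaving a hydrogen in its place does not separate the two compounds, and the amide series keeps its activity in the same measured band with either group at this position. The data offer no measurement that bears on why this step has the size it has.

What remains open is how this oxygen responds to other groups, such as a longer chain like ethyl or propyl on the oxygen, or an amine or a carboxylic acid in place of the hydroxy, since methyl and hydrogen are the only two substituents on it shown here. As far as these compounds go, it is also open whether the same methoxy to hydroxy change would read the same way on the urea of compound 1 or on the 4-chloro-3-(trifluoromethyl)phenyl amide of compound 3.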